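Swapping anilino for cyclopropylamino on a weak urea series

A few compounds are considered here, and "the series" means these few. Any claim that something is new, unique, unknown or untested is made for them only; others in the source may bear on it.

Four compounds share one core, a pyrimidine bearing an indole sulfide, a urea and a second amine. Compound 1 `O=C(Nc1ccccc1)Nc1nc(NC2CC2)cc(Sc2c[nH]c3ccccc23)n1` carries a cyclopropylamino group and a plain phenylurea; compound 2 `Cc1ccc(NC(=O)Nc2nc(Nc3ccccc3)cc(Sc3c[nH]c4ccccc34)n2)cc1` an anilino group and a 4-methylphenyl urea; compound 3 `Cc1cc(Cl)ccc1NC(=O)Nc1nc(Nc2ccccc2)cc(Sc2c[nH]c3ccccc23)n1` an anilino group and a 4-chloro-2-methylphenyl urea. In a functional assay on A549 cells (Homo sapiens) for inhibition, with a stated time of 72 h (on this read-out higher numbers stand for weaker inhibition and lower numbers for stronger inhibition), compound 2 gives 23500 nM. For compound 1 this assay reports only a limit, > 50000 nM. For compound 3 the same assay again reports only a limit, > 50000 nM. Among the measured compounds shown here, the one measured step is an at least 2.1-fold higher number from compound 2 to compound 3 (0.32 log units; beyond the scatter), and because the limit of > 50000 nM in this assay, at which 2 of the 3 values shown sit, the true size of that step is unknown. Compound 3 therefore stands at the weak edge of what this assay can resolve.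

Compound 4 `Cc1cc(Cl)ccc1NC(=O)Nc1nc(NC2CC2)cc(Sc2c[nH]c3ccccc23)n1` differs from compound 3 in one place: cyclopropyl in place of phenyl on a nitrogen on an aromatic ring. For the measured compounds named here, no measured step isolates this change; compound 1 and compound 2 differ in two places, so their values can only be noted side by side. Since compound 3 already sits at the limit, the step that the limit leaves unreadable from compound 3 to compound 4 is expected to leave compound 4 at or beyond that limit as well. Compound 4 is estimated at 80000 nM, within 30000 nM to 300000 nM.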

Compound 4, half-maximal inhibitory concentration: 31500 nM
Estimate against measurement, compound 4: 2.5-fold (0.40 log units) above; the measured number falls inside the stated range.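

Of the two compounds with the cyclopropylamino group, only compound 4 gives a number in this assay, 31500 nM, so on the 4-chloro-2-methylphenyl urea the phenyl on this nitrogen is not needed for a measurable reading. Swapping phenyl for cyclopropyl gives an at least 1.5-fold lower number from compound 3 to compound 4 (0.20 log units; that floor lies within the scatter), and changing the urea group with the cyclopropylamino group held constant gives an at least 1.5-fold lower number from compound 1 to compound 4 (0.20 log units; that floor lies within the scatter), so the value of compound 4 can be read against both neighbours, though neither step is shown to go beyond the scatter. Both steps start from a limit rather than a number, and their true sizes stay unknown because of that limit: the limit of > 50000 nM in this assay, at which 2 of the 4 values shown sit.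

From the compounds shown here alone, it remains open whether cyclopropyl in place of phenyl would change the reading on the 4-methylphenyl urea of compound 2, where the anilino compound gives a number and the step could be sized. Going by these compounds, it also remains open how a cyclohexyl group or a 2-hydroxyethyl chain on the same nitrogen would read in this assay.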